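From methoxy to bromo in a cytotoxicity series

A few compounds are considered here, and "the series" means these few. Any claim that something is new, unique, unknown or untested is made for them only; others in the source may bear on it.

- Compound 1 `Cc1cn(-c2csc(Nc3ccc(Br)cc3)n2)c(C)n1`: 45000 nM
- Compound 2 `COc1ccc(Nc2nc(-n3ccnc3C)cs2)cc1`: > 100000 nM (a limit of the assay, not a number)

Of the compounds shown here, two have been tested in a functional assay on RKO cells (Homo sapiens) for cytotoxicity, read by resazurin assay, with a stated time of 72 h; a lower number here means a stronger inhibitor, a higher number a weaker inhibitor. Compound 2 has no numerical result there, only the limit > 100000 nM. This means its position can be described only by that limit, and the record for the pair reads: the limit of > 100000 nM in this assay, at which 1 of the 2 values shown sits.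

The next compound to be measured is compound 3 `Cc1nccn1-c1csc(Nc2ccc(Br)cc2)n1`. It differs from compound 2 by bromo in place of methoxy on an aromatic carbon of a six-membered aromatic ring of carbon only, para to a large group (bromo in place of methoxy on an aromatic carbon).

Within the data shown here, no measured step shows what this exchange does. Among the measured compounds shown here, the only guide is compound 1, which also carries bromo and gives 45000 nM in this assay. On that basis, a modest move toward stronger inhibition is expected, and its size remains uncertain. The estimated step is an at least 2.0-fold lower number from compound 2 to compound 3 (0.30 log units; that floor lies within the scatter). For compound 3 the expected value is 50000 nM. The estimated range runs from 20000 nM to 100000 nM.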

Compound 3, half-maximal inhibitory concentration: > 100000 nM
Compound 3: only a limit was reported; the forecaster's own chance of this, stated with the estimate: 25%; middle value at least 2.0-fold (0.30 log units) away from the limit.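

In this assay compound 3 gives only > 100000 nM, which is a limit of the assay and not a number. Compound 2 also stands at a limit, so the step for bromo in place of methoxy on an aromatic carbon cannot be read, and bromo alone does not bring a measurable value to this series. What the result does show comes from the other comparison, where hydrogen in place of methyl on an aromatic carbon gives an at least 2.2-fold higher number from compound 1 to compound 3 (0.34 log units; beyond the scatter), so that among these bromo compounds the extra methyl of compound 1 goes with the only numerical result, and the series now reads: the limit of > 100000 nM in this assay, at which 2 of the 3 values shown sit.

From the compounds shown here alone, compounds 2 and 3 cannot be placed in any order relative to each other, and how far either lies beyond the limit remains unknown. Also open, going by these compounds, are whether methoxy gives a numerical result when that methyl is present, and what an amine or a carboxylic acid in place of bromo would do on the core of compound 1.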